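Swapping Phenyl for 5-Methylthiophen-2-yl in Compound 2

The source may report more compounds than this note shows. Statements on the series, on what has been measured and on what is new or still open speak of the compounds shown alone.

Of the compounds shown here, three with a phenyl group have been tested so far. In a functional assay on HeLa cells (Homo sapiens) for antiproliferative activity, read by MTT assay, with a stated time of 48 h (on this read-out higher numbers stand for weaker inhibition of growth and lower numbers for stronger inhibition of growth), compound 1 `CCOc1cc(NC(=O)CCCCCC(=O)Nc2cc(-c3ccccc3)ccc2N)cc2c1OCC([N+](=O)[O-])=C2` gives 19800 nM and compound 3 `CCOc1cc(NC(=O)CCCCCCC(=O)Nc2cc(-c3ccccc3)ccc2N)cc2c1OCC([N+](=O)[O-])=C2` gives 16200 nM, two values within the usual scatter of each other. Compound 2 `CCOc1cc(NC(=O)CCCCC(=O)Nc2cc(-c3ccccc3)ccc2N)cc2c1OCC([N+](=O)[O-])=C2` has no exact number and stands at a limit of the assay, > 20000 nM. Compound 4 `CCOc1cc(NC(=O)CCCCC(=O)Nc2cc(-c3ccc(C)s3)ccc2N)cc2c1OCC([N+](=O)[O-])=C2` carries 5-methylthiophen-2-yl in place of phenyl on an aromatic carbon. Among the compounds with values here, no measured pair shows what this swap does, so no shift beyond the scatter is expected in this assay. The estimated change is an at least 1.2-fold lower number from compound 2 to compound 4 (0.09 log units; that floor lies within the scatter). For compound 4 the expected value is 16000 nM, with an estimated range from 7000 nM to 32000 nM.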

Compound 4, concentration for 50% growth inhibition: 18400 nM
Compound 4: the middle estimate sits 1.2-fold (0.06 log units) below what was measured, within the range that was stated.
By their numbers in this assay, from the lowest: compounds 3, 4 and 1 (each within the scatter of the next). At a limit, above all of these: compound 2.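

Replacing phenyl with 5-methylthiophen-2-yl, on an aromatic carbon para to an amino group, gives an at least 1.0-fold lower number from compound 2 to compound 4 (0.03 log units; that floor lies within the scatter) in this assay. Compound 4 thus gives this position its first exact number with a ring other than phenyl. The true size of the step stays unknown because compound 2 has no exact number, only a limit: the limit of > 20000 nM in this assay, at which 1 of the 4 values shown sits.

From the compounds shown here alone, whether an amine or a carboxylic acid on the ring at this position would move the number beyond the scatter remains open. So does the effect of this swap on a longer chain, where the phenyl compounds have exact numbers.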